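A few compounds are considered here, and "the series" means these few. Any claim that something is new, unique, unknown or untested is made for them only; others in the source may bear on it.

In an ADME assay on HepG2 cells (Homo sapiens) for cytotoxicity (on this read-out lower numbers stand for an effect already at smaller amounts and higher numbers for an effect only at larger amounts of compound), compound 1 (`Cc1ccc(S(=O)(=O)N[C@@H](CC(=O)NC(C)(C)C)C(=O)NCCNC(=O)Nc2ccccc2)cc1`) gives > 11000 nM, which is a limit of the assay and not a number. Compound 2 (`Cc1ccc(S(=O)(=O)N[C@@H](CC(=O)NC(C)(C)C)C(=O)NCCNC(=O)c2cccc(C(C)C)c2)cc1`) gives > 11000 nM, and this too is only a limit. Going by the values given here, compound 2 therefore has no exact position on this scale, and the one other value shown offers no numerical comparison. Among the compounds with values here, the only measured step that bears on the next change is a step that the two limits leave unreadable from compound 1 to compound 2, with 3-isopropylphenyl in place of anilino on a carbonyl carbon. Both compounds share one ceiling: the limit of > 11000 nM in this assay, at which 2 of the 2 values shown sit.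

Compound 3 (`COc1cccc(C(=O)NCCNC(=O)[C@H](CC(=O)NC(C)(C)C)NS(=O)(=O)c2ccc(C)cc2)c1`) keeps the shared core but carries methoxy in place of isopropyl on an aromatic carbon, meta to a large group: methoxy in place of isopropyl on an aromatic carbon. The measured step gives no size to carry over, so no step beyond the scatter is expected in this assay, in either direction. The expected change is a step that the limit leaves unreadable from compound 2 to compound 3. For compound 3, the estimated value is 15000 nM, with an expected range from 9000 nM to 30000 nM, and a report as a limit is the likeliest outcome.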

Compound 3, half-maximal effective concentration: > 11000 nM
Compound 3 ended at the assay's limit; the forecaster's own chance of this, stated with the estimate: 85%; the middle value is on the limit's open side.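

In this assay compound 3 gives > 11000 nM, which is a limit of the assay and not a number, so neither its step from compound 2 nor its step from compound 1 can be read. The compounds shown leave open where any of them would show an effect and whether these changes alter it: the limit of > 11000 nM in this assay, at which 3 of the 3 values shown sit.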